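This account rests on a few compounds, and the source may have more. Where it says the series, first, only, none or still open, it means among the compounds named here.

Cytotoxicity across this small set is followed in a functional assay on CCRF-CEM cells (Homo sapiens) for cytotoxicity; a higher number here means that more compound is tolerated, a lower number that less compound is tolerated. For compound 1 `Cc1ccc(Cc2ncn3c(O)ncnc23)cc1` the assay reports only > 833000 nM, a limit and not a number; this is the limit of > 833000 nM in this assay, at which 1 of the 3 values shown sits. Compound 2 `Cc1nc(Cc2ccccc2)c2ncnc(O)n12` gives 263000 nM, and compound 3 `Cc1ncn2c(=O)[nH]c(=S)[nH]c12` gives 786000 nM. Of the two numbers, compound 3 holds the higher one and compound 2 the lower, a gap beyond the usual scatter. Compound 4 `Cc1nc(C)n2c(=O)[nH]c(=S)[nH]c12` differs from compound 3 by methyl in place of hydrogen on an aromatic carbon. For the measured compounds named here, no measured pair in the set shows what such a change does in this assay, so no step beyond the scatter is expected in either direction. Compound 4 is accordingly estimated at 700000 nM, with a range from 300000 nM to 1500000 nM. The estimate amounts to a 1.1-fold lower number from compound 3 to compound 4 (0.05 log units; within the scatter), expected to sit within the scatter.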

Compound 4, half-maximal cytotoxic concentration: 526000 nM
Compound 4: middle estimate off by 1.3-fold (0.12 log units), on the high side; the measured number falls inside the stated range.
By their numbers in this assay, from the lowest: compounds 2, 4 and 3 (each within the scatter of the next, the first and the last beyond it). At a limit, above all of these: compound 1.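

In this assay, for the compounds shown here, methyl in place of hydrogen on an aromatic carbon, between two ring nitrogen atoms, gives a 1.5-fold lower number from compound 3 to compound 4 (0.17 log units; within the scatter), the first measured pair in the set for this change at this position. No shift beyond the scatter appears at this carbon on the core of compound 3. Nothing on record bears on the size of this step.

Going by these compounds, whether a longer chain, an amine or a carboxylic acid at this carbon would shift the number beyond the scatter stays open. So does the effect of the same methyl on the core of compound 1.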